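Pyridin-4-yl in place of 4-ethylphenyl on the carbonyl

The source may hold more compounds than are shown below. What is called first, only, known or untested is meant among the compounds shown, and "the series" means these compounds.

Measured so far:
- compound 1, `CCc1ccc(C(=O)N2CCN(Cc3nc4ccccc4n3Cc3cccc(C)c3)CC2)cc1`: 67%
- compound 2, `CC(C)CCn1c(CN2CCN(C(=O)c3ccco3)CC2)nc2ccccc21`: 42.1%

In an assay on isolated protein for inhibition of aldehyde dehydrogenase 1A1 (Homo sapiens), read by spectrophotometry, tested at 10 uM (a lower number here means less inhibition, a higher number more inhibition at the concentration tested (going by the name of the read-out)), compound 1 gives 67%, the higher of the two numbers seen; compound 2 gives 42.1%, a gap beyond the usual scatter. Compound 2 differs from compound 1 in more than one place, so no single step can be read from the pair; the two values only show that a smaller heteroaromatic group on the carbonyl, together with a different group on the core, went with the lower number.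

Compound 3, `Cc1cccc(Cn2c(CN3CCN(C(=O)c4ccncc4)CC3)nc3ccccc32)c1`, differs from compound 1 in one place: pyridin-4-yl in place of 4-ethylphenyl on a carbonyl carbon.

Among the compounds with values here, for this assay the step from compound 1 to compound 3 is expected to be a drop of moderate size, a number 22 percentage points lower from compound 1 to compound 3 (beyond the scatter), since the only other compound with a heteroaromatic group on the carbonyl, compound 2, sits at 42.1%. Compound 3 is therefore estimated at 45%, within 25% to 65%.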

Compound 3, a percentage reported as inhibition, at one concentration (the size of the read-out at that concentration, not a potency): 20.6%
For compound 3 the middle estimate is 24.4 percentage points above the measured one; the measured number lies below the stated range.
By their numbers in this assay, from the lowest: compound 3; then compound 2; then compound 1.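

In this assay the group on the carbonyl carbon now has a reading from a single change: pyridin-4-yl in place of 4-ethylphenyl gives a number 46.4 percentage points lower from compound 1 to compound 3 (beyond the scatter) and this counts as a large step. With the rest of compound 1 held fixed, this position is clearly not indifferent to the exchange, which removes the ethyl group and brings a ring nitrogen with one hydrogen-bond acceptor into the aromatic ring. No measurement is at hand that explains the fall.

Within the data shown here, the one step cannot separate the loss of the ethyl group from the entry of the ring nitrogen; a plain phenyl or a pyridin-3-yl on the same carbonyl would begin to tell these apart. Going by these compounds, whether the step carries over to a different group on the shared core also stays open.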